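Swapping one aryl group on a shared core

The compounds below may be only part of what the source reports. "The series", "measured", "known", "first", "only" and "open" are said of these compounds alone.

Compound 1 `COc1cc(C(=O)c2cn(-c3ccccc3)cc2-c2ccc(Br)cc2)cc(OC)c1OC` gives 340 nM
Compound 2 `COc1ccccc1-c1cn(-c2ccccc2)cc1C(=O)c1cc(OC)c(OC)c(OC)c1` gives 190 nM
Compound 3 `COc1cc(C(=O)c2cn(-c3ccccc3)cc2-c2c(F)cc(F)cc2F)cc(OC)c1OC` has no measurement yet

In a functional assay on MCF7 cells (Homo sapiens) for cytotoxicity, read by MTT assay, with a stated time of 96 h (a higher number here means a weaker inhibitor, a lower number a stronger inhibitor), compound 2 gives 190 nM and sits within the scatter of compound 1. The change to compound 3 is counted in 2,4,6-trifluorophenyl in place of 2-methoxyphenyl on an aromatic carbon and puts 2,4,6-trifluorophenyl in place of 2-methoxyphenyl on an aromatic carbon. Among the compounds with values here, the one measured step at this carbon is a 1.8-fold lower number from compound 1 to compound 2 (0.25 log units; within the scatter) and offers the only guide. No step beyond the scatter is therefore expected in this assay for this untested group. The expected step is a 1.2-fold higher number from compound 2 to compound 3 (0.08 log units; within the scatter) and remains an estimate. Compound 3 is expected at 230 nM with an estimated range of 70 nM to 700 nM for repeat measurements.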

Compound 3, half-maximal inhibitory concentration: 180 nM
Compound 3: the middle estimate sits 1.3-fold (0.11 log units) above what was measured; the measured number falls inside the stated range.
By their numbers in this assay, from the lowest: compounds 3, 2 and 1 (each within the scatter of the next).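

Across the three aryl groups at this carbon, a 1.1-fold lower number from compound 2 to compound 3 (0.02 log units; within the scatter) and a 1.9-fold lower number from compound 1 to compound 3 (0.28 log units; within the scatter) both stay within the scatter in this assay. Trading 2-methoxyphenyl, with its hydrogen-bond acceptor, for 2,4,6-trifluorophenyl, which has none, therefore brings no readable change, and a third aryl group now fits this flat picture. No evidence here explains why these groups read alike. On these data alone, what stays open is whether anything at this carbon moves the number beyond the scatter. A phenyl ring bearing an amine or a carboxylic acid, or a cyclohexyl group with no aromatic ring, would test that.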